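The source may hold more compounds than are shown below. What is called first, only, known or untested is meant among the compounds shown, and "the series" means these compounds.

Compound 2 `CC(C)N1CCC(COc2ccc(-c3nc4ccc(Oc5ccc(Cl)cc5)cc4o3)cc2)CC1` and compound 1 `CCN1CCC(Oc2ccc(-c3nc4ccc(Oc5ccc(Cl)cc5)cc4o3)cc2)CC1` share one core and differ only in the group attached through an oxygen on an aromatic ring. In an assay on isolated protein for inhibition of advanced glycosylation end product-specific receptor (Homo sapiens), read by FRET, with stated times of 30 min and 1 h, tested at 4 uM (on this read-out lower numbers stand for less inhibition and higher numbers for more inhibition at the one concentration tested (going by the name of the read-out)), compound 1 gives 15.3%, while compound 2 gives 26.2%, the higher of the two numbers; the step of a number 10.9 percentage points higher from compound 1 to compound 2 (beyond the scatter) lies beyond the scatter, so compound 2 stands above compound 1. Compound 3 `CN(C)CCCOc1ccc(-c2nc3ccc(Oc4ccc(Cl)cc4)cc3o2)cc1` has not yet been measured. It differs from compound 2 in one place: 2-(dimethylamino)ethyl in place of 1-isopropylpiperidin-4-yl on a saturated chain carbon bound to an oxygen on an aromatic ring. Within the data shown here, the only measured step that touches this part of the molecule is a number 10.9 percentage points higher from compound 1 to compound 2 (beyond the scatter), which kept the ring and altered what sits on its nitrogen. Among the measured compounds shown here, the present change removes the ring altogether, a larger alteration than the one measured, so no measured pair points clearly. Compound 2 gave the higher number, 26.2%, with the ring in place, so some fall is expected when the ring is lost. Compound 3 is therefore expected to show a step of a number 8.2 percentage points lower from compound 2 to compound 3 (within the scatter). For compound 3 the estimated value is 18%, within a range from 5% to 32%.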

Compound 3, a percentage reported as inhibition, at one concentration (the size of the read-out at that concentration, not a potency): 4.9%
The estimate for compound 3 lay 13.1 percentage points above the measured number; measured number outside the range, below it.
By their numbers in this assay, from the lowest: compound 3; then compound 1; then compound 2.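

Swapping 1-isopropylpiperidin-4-yl for 2-(dimethylamino)ethyl on a saturated chain carbon bound to an oxygen on an aromatic ring gives, in this assay, a number 21.3 percentage points lower from compound 2 to compound 3 (beyond the scatter) and so shows that this part of the molecule does not accept every group that carries an amine nitrogen equally. The open chain also falls short of the other ring-bearing compound, with a number 10.4 percentage points lower from compound 1 to compound 3 (beyond the scatter) in the same comparison, so among these three compounds both of those with a six-membered non-aromatic ring stand above the one with no ring, and none goes against this. No independent measurement accompanies these numbers to account for the drop.

The ring is not the only thing that changes here, since the group entering is also smaller in heavy atoms, and the compounds shown cannot separate these two changes. A 3-(piperidin-1-yl)propyl group, which keeps the open chain but carries a ring on its nitrogen, would help to show which of the two matters more.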